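This account rests on a few compounds, and the source may have more. Where it says the series, first, only, none or still open, it means among the compounds named here.

Measured compounds:
- Compound 1, `Cn1cnc(-c2nc(N)c3cc(Cc4ccccc4)sc3n2)c1`: 2330 nM
- Compound 2, `Nc1nc(-c2cccc(F)c2)nc2sc(Cc3ccccc3)cc12`: 123 nM

For the measured compounds named here, in a functional assay on CHO-K1 cells for antagonist activity at adenosine receptor A1 (Homo sapiens), read by a beta-galactosidase reporter and cAMP accumulation, with stated times of 15 min and 6 h (a higher number here means a weaker inhibitor, a lower number a stronger inhibitor), compound 2 gives the lowest of the two numbers; the only neighbour is compound 1, which gives a higher number, and the step of a 19-fold lower number from compound 1 to compound 2 (1.28 log units; beyond the scatter) is large and well beyond the scatter. Compound 3, `N#Cc1cccc(-c2nc(N)c3cc(Cc4ccccc4)sc3n2)n1`, is not yet measured in this assay. It differs from compound 2 in one place: 6-cyanopyridin-2-yl in place of 3-fluorophenyl on an aromatic carbon. Going by the values given here, the only measured step that bears on this change is the one from a five-membered heteroaryl with ring nitrogen to a plain six-membered carbon ring, a 19-fold lower number from compound 1 to compound 2 (1.28 log units; beyond the scatter); the reverse direction, a carbon ring replaced by a ring carrying a hetero atom and an added nitrile, has no direct precedent here, and the group entering is six-membered rather than five-membered. On that single step the expectation is a move toward a higher number, smaller than the measured one, as a 3.3-fold higher number from compound 2 to compound 3 (0.51 log units; beyond the scatter). The estimate for compound 3 in this assay is 400 nM, with a range from 100 nM to 1600 nM.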

Compound 3, inhibition constant: > 1000 nM
Compound 3 was reported as a limit; the forecaster's own chance of this, stated with the estimate: 5%; middle value at least 2.5-fold (0.39 log units) away from the limit.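

In this assay, the position between two ring nitrogen atoms now has a second replacement for 3-fluorophenyl: 6-cyanopyridin-2-yl gives an at least 8.1-fold higher number from compound 2 to compound 3 (0.91 log units; beyond the scatter), so a six-membered ring with one hetero atom and a nitrile does not hold the number of the carbon-only ring. Across the three compounds, both rings carrying ring nitrogen stand on the higher side of compound 2, whether five-membered as in compound 1 or six-membered as in compound 3, and no compound shown goes against this. The figure for compound 3 is a limit and not a number, and the step between compound 1 and compound 3 cannot be read, which leaves the order of those two rings undecided: the limit of > 1000 nM in this assay, at which 1 of the 3 values shown sits.

The change from compound 2 to compound 3 alters the ring atom and the substituent together, so the compounds shown do not separate the ring nitrogen from the nitrile; a 3-cyanophenyl or an unsubstituted pyridin-2-yl at this position would divide the two. On these data alone, how an unsubstituted phenyl or a 3-methoxyphenyl would stand against 3-fluorophenyl also remains open.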